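A few compounds are considered here, and "the series" means these few. Any claim that something is new, unique, unknown or untested is made for them only; others in the source may bear on it.

In an ADME assay on HepG2 cells (Homo sapiens) for cytotoxicity, read by MTT assay, with a stated time of 72 h (a higher number here means that more compound is tolerated, a lower number that less compound is tolerated), compound 3 `O=[N+]([O-])c1c(CS(=O)(=O)c2ccccc2)nc2c(C#Cc3ccc(CO)cc3)cc(Cl)cn12` gives > 15600 nM, which is a limit and not a number. Compound 1 `O=[N+]([O-])c1c(CS(=O)(=O)c2ccccc2)nc2c(C#Cc3ccccc3)cc(Cl)cn12` also gives only a limit, > 3900 nM. Compound 2 `COc1ccc(C#Cc2cc(Cl)cn3c([N+](=O)[O-])c(CS(=O)(=O)c4ccccc4)nc23)cc1` likewise gives only a limit, > 3900 nM. No exact reading is therefore available for any of these compounds.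

Compound 4 `O=[N+]([O-])c1c(CS(=O)(=O)c2ccccc2)nc2c(C#CC3(O)CCCC3)cc(Cl)cn12` keeps the shared core but carries 1-hydroxycyclopentyl in place of 4-(hydroxymethyl)phenyl on a triple-bonded carbon.

Among the measured compounds shown here, three measured steps bear on this change, though only loosely, since each alters a group on an aromatic carbon and none replaces the whole ring. They are a step that the two limits leave unreadable from compound 1 to compound 2, a step that the two limits leave unreadable from compound 1 to compound 3 and a step that the two limits leave unreadable from compound 2 to compound 3. With no readable size among them, they point to no direction, so no step beyond the usual scatter is expected in this assay. The estimated step is a step that the limit leaves unreadable from compound 3 to compound 4. This expectation is anchored on compound 3, whose limit of > 15600 nM is the only starting point, and another limit is the likeliest report. Compound 4 is estimated at 20000 nM, with an expected range of 7000 nM to 60000 nM.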

Compound 4, half-maximal cytotoxic concentration: > 31300 nM
Compound 4 gave a limit, no number; the forecaster's own chance of this, stated with the estimate: 75%; at least 1.5-fold (0.19 log units) between middle value and limit.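

Among the compounds shown here, compound 4 gives only a limit, as do compound 1, compound 2 and compound 3, so no step from any of these three to compound 4 can be read. The compounds shown leave open how much of each is actually tolerated in this assay, and whether changing the group on the triple-bonded carbon alters it.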